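Compound 3: bromo in place of chloro

The source may report more compounds than this note shows. Statements on the series, on what has been measured and on what is new or still open speak of the compounds shown alone.

- compound 1 `O=C(NNc1ccnc2cc(Cl)ccc12)c1ccccc1/N=C/c1ccccc1Cl`: 5.5
- compound 2 `O=C(NNc1ccnc2cc(Cl)ccc12)c1ccccc1/N=C/c1ccc(Cl)cc1`: 5.62

These readings come from a physicochemical assay for lipophilicity, measured as octanol-water partition; on this read-out higher numbers stand for higher lipophilicity and lower numbers for lower lipophilicity. Compound 2 sits within the scatter of compound 1, with a number 0.12 log units higher from compound 1 to compound 2 (within the scatter). Within the data shown here, that step, 4-chlorophenyl in place of 2-chlorophenyl, is the only one measured, and it keeps the chlorine, so no measured step shows what a bromo swap does. Compound 3 `O=C(NNc1ccnc2cc(Cl)ccc12)c1ccccc1/N=C/c1ccc(Br)cc1` carries bromo in place of chloro on an aromatic carbon, para to a large group. The estimate is a number 0.13 log units higher from compound 2 to compound 3 (within the scatter), a slight rise that is not expected to pass the scatter in this assay. For compound 3 the expected value is 5.75, with a range of 5.45 to 6.05.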

Compound 3, partition coefficient: 5.76
Compound 3: the middle estimate sits 0.01 log units below what was measured; low and high end bracket the measured number.
By their numbers in this assay, from the lowest: compounds 1, 2 and 3 (each within the scatter of the next).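

In this assay, changing the halogen itself, with bromo in place of chloro on an aromatic carbon para to a large group, gives a number 0.14 log units higher from compound 2 to compound 3 (within the scatter) and so does not separate the two halogens at this position. Changing the halogen and its place together, with 4-bromophenyl in place of 2-chlorophenyl, gives a number 0.26 log units higher from compound 1 to compound 3 (within the scatter) and also stays inside the usual scatter. No further measurement offers an explanation for these small steps.

From the compounds shown here alone, what remains open is whether a very different group in this place, such as an amine or a carboxylic acid, would move the number beyond the scatter.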